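Unbound fraction: from compound 2 to compound 4

The source may hold more compounds than are shown below. What is called first, only, known or untested is meant among the compounds shown, and "the series" means these compounds.

Three compounds of the series have a number in an ADME assay on a cell-free system (plasma) for protein binding; on this read-out lower numbers stand for a smaller free fraction and higher numbers for a larger free fraction. Compound 1 `COc1cc2nnc(C(N)=O)c(Nc3ccc(F)cc3F)c2cc1OC` gives 0.045. Compound 2 `CCOc1cc2nnc(C(N)=O)c(Nc3ccc(C)cc3F)c2cc1N1CCN(C)CC1` gives 0.016, the lowest of the three; compound 1 is the nearest to it, beyond the scatter. Among the measured compounds shown here, compound 3 `CCOc1cc2nnc(C(N)=O)c(Nc3cc(C)ccc3F)c2cc1N1CCN(C)CC1` gives 0.11, the highest, and the only single-point step measured is a 6.9-fold higher number from compound 2 to compound 3 (0.84 log units; beyond the scatter), a modest shift from moving the methyl on the same ring.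

Compound 4 `CCOc1cc2nnc(C(N)=O)c(Nc3cccc(Cl)c3Cl)c2cc1N1CCN(C)CC1` differs from compound 2 in one place: 2,3-dichlorophenyl in place of 2-fluoro-4-methylphenyl on a nitrogen on an aromatic ring. For the measured compounds named here, no measured step exchanges this ring for a dichlorophenyl, so the step from compound 2 to compound 3 bears on it only in showing that a change on this ring can move this assay beyond the scatter. With nothing pointing in either direction, the expected step in this assay is a 1.3-fold higher number from compound 2 to compound 4 (0.10 log units; within the scatter), within the scatter, with a wide band. For compound 4 the estimate in this assay is 0.02, expected between 0.007 and 0.06.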

Compound 4, unbound fraction: < 0.017
Compound 4 ended at the assay's limit; the forecaster's own chance of this, stated with the estimate: 5%; middle value at least 1.1-fold (0.07 log units) from the limit.
By their numbers in this assay, from the lowest: compound 2; then compound 1; then compound 3.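

In this assay compound 4 gives < 0.017, a limit of the assay and not a number. The step from compound 2 to compound 4 cannot be read, so 2,3-dichlorophenyl and 2-fluoro-4-methylphenyl on this nitrogen remain unordered, with one value shown at the limit: the limit of < 0.017 in this assay, at which 1 of the 4 values shown sits. Exchanging 2-fluoro-5-methylphenyl for 2,3-dichlorophenyl gives an at least 6.4-fold lower number from compound 3 to compound 4 (0.81 log units; beyond the scatter), so the higher number seen with 2-fluoro-5-methylphenyl does not carry over to this dichlorophenyl, and changes at this place have now moved the read-out beyond the scatter in both directions.

The actual free fraction of compound 4 remains open, as does whether the higher number is specific to 2-fluoro-5-methylphenyl among the rings shown. Also open, from the compounds shown here alone, is how this assay would read with an amine or a carboxylic acid on the ring at this nitrogen.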